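Compound 2 to Compound 3 in Receptor Binding

The source may report more compounds than this note shows. Statements on the series, on what has been measured and on what is new or still open speak of the compounds shown alone.

Measured compounds:
Compound 1, `O=C(O)Cc1sc(Cc2ccccc2-c2ccccc2)nc1-c1ccc(Cl)cc1`: 41 nM
Compound 2, `O=C(O)Cc1sc(C(c2ccc(F)cc2)c2ccc(F)cc2)nc1-c1cc(F)cc(F)c1`: 35 nM

In an in vitro assay on HEK385-7 cells for displacement of a labelled ligand from prostaglandin D2 receptor 2 (Homo sapiens) (on this read-out lower numbers stand for stronger inhibition and higher numbers for weaker inhibition), compound 1 gives 41 nM and compound 2 gives 35 nM. Compound 2 carries the lowest of the two numbers, but its distance from compound 1 lies within the scatter, so the two compounds cannot be told apart on this read-out. Compound 3, `O=C(O)Cc1sc(C(c2ccc(F)cc2)c2ccc(F)cc2)nc1-c1ccnc(Cl)c1`, has not yet been measured. It differs from compound 2 in one place: 2-chloropyridin-4-yl in place of 3,5-difluorophenyl on an aromatic carbon. Going by the values given here, the set holds no measured step of this kind, so the size of the change can only be guessed. The step from compound 2 to compound 3 in this assay is expected to be small, a 1.4-fold higher number from compound 2 to compound 3 (0.15 log units; within the scatter), toward a slightly higher number, and may well stay within the scatter. Compound 3 is therefore estimated at 50 nM in this assay, with a range from 15 nM to 160 nM.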

Compound 3, half-maximal inhibitory concentration: 3.1 nM
For compound 3 the middle estimate is 16-fold (1.21 log units) above the measured one; the whole stated range lies above it.
By their numbers in this assay, from the lowest: compound 3; then compounds 2 and 1 (each within the scatter of the next).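

In this assay, going by these compounds alone, the aromatic carbon next to the ring nitrogen proves sensitive to what it carries: 2-chloropyridin-4-yl in place of 3,5-difluorophenyl gives an 11-fold lower number from compound 2 to compound 3 (1.05 log units; beyond the scatter) and so a large step, where the earlier compounds offered no step to read at all. The swap exchanges a ring of carbon only and two fluorines for a ring with one nitrogen, one hydrogen-bond acceptor and one chlorine, all in a single change, so the step cannot be divided among these parts. Nothing available here accounts for the size of the step.

The compounds shown leave open whether the ring nitrogen or the chlorine carries the step, which pyridin-4-yl and 3-chlorophenyl at this position would separate. Going by these compounds, whether a methoxy group or a nitrile could stand in for the chlorine also remains open.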